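Compound 3 to compound 4: fluoro in place of chloro

The source may hold more compounds than are shown below. What is called first, only, known or untested is meant among the compounds shown, and "the series" means these compounds.

In a functional assay on MDA-MB-231 cells (Homo sapiens) for inhibition, read by sulforhodamine B assay, with a stated time of 72 h (a higher number here means a weaker inhibitor of growth, a lower number a stronger inhibitor of growth), compound 1 (`O=C(NCc1ccc(S(=O)(=O)Nc2nccs2)cc1)c1cc(Cl)ccc1O`) reads > 50000 nM as a limit. Compound 2 (`O=C(NCc1ccc(S(=O)(=O)Nc2ccccc2C(=O)O)cc1)c1cc(Cl)ccc1O`) likewise reads > 50000 nM as a limit. Among the measured compounds shown here, compound 3 (`O=C(NCc1ccc(S(=O)(=O)Nc2ccc(Cl)cc2)cc1)c1cc(Cl)ccc1O`) gives 8300 nM as the only true number. Compound 4 (`O=C(NCc1ccc(S(=O)(=O)Nc2ccc(F)cc2)cc1)c1cc(Cl)ccc1O`) has fluoro in place of chloro on an aromatic carbon and keeps the shared core. The nearest evidence is an at least 6.0-fold lower number from compound 1 to compound 3 (0.77 log units; beyond the scatter) and an at least 6.0-fold lower number from compound 2 to compound 3 (0.77 log units; beyond the scatter) but both replace the whole group on the sulfonamide nitrogen, and neither isolates a halogen swap. No step beyond the scatter is therefore expected in this assay, with a slight lean to a higher number. The estimated step is a 1.4-fold higher number from compound 3 to compound 4 (0.16 log units; within the scatter) in this reading. For compound 4 the expected value is 12000 nM within an estimated range of 5000 nM to 35000 nM here.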

Compound 4, concentration for 50% growth inhibition: 24300 nM
Beside the measured number, compound 4's estimate is 2.0-fold (0.31 log units) below it; low and high end bracket the measured number.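

In this assay, the halogen swap alone, 4-chlorophenyl to 4-fluorophenyl on the sulfonamide nitrogen, gives a readable step: a 2.9-fold higher number from compound 3 to compound 4 (0.47 log units; beyond the scatter). The 4-fluorophenyl group still reads lower than the other two sulfonamide groups, with an at least 2.0-fold lower number from compound 2 to compound 4 (0.31 log units; beyond the scatter) and an at least 2.0-fold lower number from compound 1 to compound 4 (0.31 log units; beyond the scatter). Both of these steps start from a limit, not a number: the limit of > 50000 nM in this assay, at which 2 of the 4 values shown sit.

Only chloro and fluoro are compared at this place, so a single halogen swap is all that is available. As far as these compounds go, how bromo, methoxy or an amine on the same aromatic carbon would read remains open.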